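Cyano in Place of Hydrogen Across Two Related Cores

This account rests on a few compounds, and the source may have more. Where it says the series, first, only, none or still open, it means among the compounds named here.

Three compounds have been measured in a functional assay on A549 cells (Homo sapiens) for antiproliferative activity, read by MTT assay, with a stated time of 72 h; a higher number here means a weaker inhibitor, a lower number a stronger inhibitor:

Compound 1 `CC/C=C\C(=O)Nc1cc(Nc2nccc(-c3cn(C)c4ccccc34)n2)c(OC)cc1N(C)CCN(C)C` gives 1530 nM
Compound 2 `CC/C=C\C(=O)Nc1cc(Nc2ncc(C#N)c(-c3cn(C)c4ccccc34)n2)c(OC)cc1N(C)CCN(C)C` gives 162 nM
Compound 3 `C=CC(=O)Nc1cc(Nc2nccc(-c3cn(C)c4ccc(F)cc34)n2)c(OC)cc1N(C)CCN(C)C` gives 329 nM

In this assay the step of a 9.4-fold lower number from compound 1 to compound 2 (0.98 log units; beyond the scatter) came from a single alteration: cyano in place of hydrogen on an aromatic carbon. Compound 4 `C=CC(=O)Nc1cc(Nc2ncc(C#N)c(-c3cn(C)c4ccc(F)cc34)n2)c(OC)cc1N(C)CCN(C)C` has not yet been measured; it stands to compound 3 as compound 2 stands to compound 1, through the change (cyano in place of hydrogen on an aromatic carbon). The two places are of the same kind but not identical: in compound 1 the cyano enters ortho to a 1-methyl-1H-indol-3-yl group, in compound 3 ortho to a 5-fluoro-1-methyl-1H-indol-3-yl group. How the core of compound 3 differs from that of compound 1 is not broken down here; what the numbers show is that compound 3 gives a lower number than compound 1 in this assay. If the change repeats what it did the first time, it is expected to give a 7.3-fold lower number from compound 3 to compound 4 (0.86 log units; beyond the scatter), resting on the single earlier step of a 9.4-fold lower number from compound 1 to compound 2 (0.98 log units; beyond the scatter); with one precedent on a different core, that expectation is held loosely. Compound 4 is estimated at 45 nM, in a range from 15 nM to 130 nM.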

Compound 4, half-maximal inhibitory concentration: 9700 nM
Compound 4: the middle estimate sits 220-fold (2.33 log units) below what was measured; the measured number lies above the stated range.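

In this assay the same exchange of hydrogen for cyano gave a 29-fold higher number from compound 3 to compound 4 (1.47 log units; beyond the scatter), so the lower number seen on the core of compound 1 did not carry over to the core of compound 3. The two steps run in opposite directions, and the gap between them is larger than scatter can account for: the same change on two cores in this assay, a 9.4-fold lower number (0.98 log units; beyond the scatter) from compound 1 to compound 2 and a 29-fold higher number (1.47 log units; beyond the scatter) from compound 3 to compound 4, 280-fold (2.44 log units) apart, beyond the scatter of two such steps. This shows that, in this series, the effect of cyano at this place depends on the surrounding structure, but with one pair on each core it does not show which feature is responsible, since compound 1 and compound 3 differ both in the amide chain and in the fluoro group on the indole.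

As far as these compounds go, what remains open is whether the reversal follows the fluoro group or the shorter amide chain, which a compound combining the 5-fluoro-1-methyl-1H-indol-3-yl group with the longer chain of compound 1 could help separate. Also open, from the compounds shown here alone, is whether chloro or trifluoromethyl at the place of the cyano would follow the same course on either core.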